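Hydroxyphenyl for dichlorophenyl on an acrylanilide-type stilbene

A few compounds are considered here, and "the series" means these few. Any claim that something is new, unique, unknown or untested is made for them only; others in the source may bear on it.

Measured compounds:
Compound 1 `CC/C(=C(\c1ccccc1)c1ccc(NC(=O)C(C)C)cc1)c1ccc(Cl)cc1Cl` gives 8300 nM in a functional assay on MCF7 cells (Homo sapiens) for inhibition, read by trypan blue exclusion, with a stated time of 72 h; on this read-out higher numbers stand for weaker inhibition of growth and lower numbers for stronger inhibition of growth.
Compound 2 `CC/C(=C(\c1ccc(NC(=O)C(C)C)cc1)c1ccc(OC)cc1)c1ccc(O)cc1` gives 9000 nM in this assay.
Compound 3 `CC/C(=C(\c1ccc(NC(=O)C(C)C)cc1)c1ccc(OC)cc1)c1ccc(Cl)cc1Cl` gives 13200 nM in this assay.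

The three numbers lie close together, and the difference between the core of compound 1 and that of compound 3 is not broken down here. One change is seen once among the measured compounds: 4-hydroxyphenyl in place of 2,4-dichlorophenyl on a double-bonded chain carbon bound to a double-bonded chain carbon and a saturated chain carbon. It made a 1.5-fold lower number from compound 3 to compound 2 (0.17 log units; within the scatter).

Compound 4 `CC/C(=C(\c1ccccc1)c1ccc(NC(=O)C(C)C)cc1)c1ccc(O)cc1` is not yet measured. It arises from compound 1 by the same change, (4-hydroxyphenyl in place of 2,4-dichlorophenyl on a double-bonded chain carbon bound to a double-bonded chain carbon and a saturated chain carbon). Because compound 2 and compound 3 showed a 1.5-fold lower number from compound 3 to compound 2 (0.17 log units; within the scatter), a step of similar size is expected from compound 1 to compound 4, namely a 1.4-fold lower number from compound 1 to compound 4 (0.14 log units; within the scatter). On that basis compound 4 is estimated at 6000 nM in this assay, with a likely range from 2500 nM to 14000 nM.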

Compound 4, concentration for 50% growth inhibition: 8100 nM
Compound 4: middle estimate off by 1.4-fold (0.13 log units), on the low side; the range from low to high includes it.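

In this assay, 4-hydroxyphenyl in place of 2,4-dichlorophenyl gave a 1.0-fold lower number from compound 1 to compound 4 (0.01 log units; within the scatter). Set beside the earlier step on the other core, the two steps agree: the same change on two cores in this assay, a 1.5-fold lower number (0.17 log units; within the scatter) from compound 3 to compound 2 and a 1.0-fold lower number (0.01 log units; within the scatter) from compound 1 to compound 4, 1.4-fold (0.16 log units) apart, within the scatter of two such steps. This shows that the change left the number within the scatter on both cores, with no sign that the two cores respond differently, but it does not show that the change moves the number at all, and steps this small are a weak test of whether an effect carries over.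

The compounds shown leave open whether a different group at this place, such as an amine or a carboxylic acid, would give a step beyond the scatter. They also leave open how this change would behave on any other core.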